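A few compounds are considered here, and "the series" means these few. Any claim that something is new, unique, unknown or untested is made for them only; others in the source may bear on it.

Going by the values given here, in a functional assay on DU-145 cells (Homo sapiens) for cytotoxicity, read by sulforhodamine B assay, with a stated time of 48 h (a higher number here means a weaker inhibitor of growth, a lower number a stronger inhibitor of growth), compound 3 `CN1CCN(c2nc(Nc3ccc(C#N)c(C(F)(F)F)c3)nc(Oc3ccnc4ccccc34)n2)CC1` gives 51200 nM, the only outright number among the three measured compounds. Compound 1 `N#Cc1ccc(Nc2nc(Oc3ccnc4ccccc34)nc(N3CCN(c4ccccc4)CC3)n2)cc1C(F)(F)F` reaches only the limit of this assay, > 100000 nM. Compound 2 `COc1ccc(N2CCN(c3nc(Nc4ccc(C#N)c(C(F)(F)F)c4)nc(Oc4ccnc5ccccc45)n3)CC2)cc1` likewise stops at the limit, > 100000 nM. The two measured steps leading to compound 3 therefore carry only a floor: an at least 1.9-fold lower number from compound 1 to compound 3 (0.29 log units; that floor lies within the scatter), and an at least 1.9-fold lower number from compound 2 to compound 3 (0.29 log units; that floor lies within the scatter). Both describe the same kind of change, an aromatic ring on the ring nitrogen being replaced by methyl, and both point to a lower number, though the floor alone lies within the scatter; the evidence the limit of > 100000 nM in this assay, at which 2 of the 3 values shown sit, shows how little can be read from them.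

Compound 4 `N#Cc1ccc(Nc2nc(Oc3ccnc4ccccc34)nc(N3CCN(c4ccc(F)cc4)CC3)n2)cc1C(F)(F)F` differs from compound 3 in one place: 4-fluorophenyl in place of methyl on an amine nitrogen in a ring. Among the compounds with values here, this runs the earlier steps backward, restoring an aromatic ring on that nitrogen. In this assay the expectation is therefore a higher number for compound 4, with a 2.3-fold higher number from compound 3 to compound 4 (0.37 log units; beyond the scatter), quite possibly returning to the limit. Compound 4 is estimated at 120000 nM, within a range from 30000 nM to 400000 nM.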

Compound 4, concentration for 50% growth inhibition: > 100000 nM
Compound 4 was reported as a limit (the forecaster's own chance of this, stated with the estimate: 65%); the middle value does not contradict the limit.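

Compound 4 puts a third kind of aromatic ring on the amine nitrogen in a ring, and with 4-fluorophenyl there it also sits at the limit of this assay, as do the compounds carrying phenyl and 4-methoxyphenyl. Going by these compounds alone, the change from methyl to 4-fluorophenyl gives an at least 1.9-fold higher number from compound 3 to compound 4 (0.29 log units; that floor lies within the scatter), so the reverse direction now agrees with the earlier steps, yet it too is only a floor. The steps among compound 1, compound 2 and compound 4 cannot be read, so hydrogen, methoxy and fluoro on that aromatic ring cannot be told apart: the limit of > 100000 nM in this assay, at which 3 of the 4 values shown sit.

The compounds shown leave open whether anything on that nitrogen gives a clearly lower number than compound 3 does. An ethyl group, a benzyl group or a plain hydrogen there could begin to answer this.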